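Amide substituent change on the long-linker analogue

The source may report more compounds than this note shows. Statements on the series, on what has been measured and on what is new or still open speak of the compounds shown alone.

Compound 1 `CCCCc1oc2ccccc2c1C(=O)c1ccc(OCC(=O)NC(C)C)cc1`: 360 nM
Compound 2 `CCCCNC(=O)CCCOc1ccc(C(=O)c2c(CCCC)oc3ccccc23)cc1`: > 50000 nM

In a functional assay on HL-60 cells (Homo sapiens) for antiproliferative activity, read by MTT assay, with a stated time of 24 h (on this read-out lower numbers stand for stronger inhibition and higher numbers for weaker inhibition), compound 1 gives 360 nM. Compound 2 reaches only the limit of this assay, > 50000 nM, as the limit of > 50000 nM in this assay, at which 1 of the 2 values shown sits, records. Going by the values given here, the single measured step, an at least 130-fold higher number from compound 1 to compound 2 (2.14 log units; beyond the scatter), changes both the chain and the amide substituent at once, so it bears only indirectly on what follows. Compound 3 `CCCCc1oc2ccccc2c1C(=O)c1ccc(OCCCC(=O)N[C@@H](C)c2ccccc2)cc1` keeps the chain of compound 2 and differs by 1-phenylethyl in place of butyl on an amide-type nitrogen. Among the compounds with values here, no measured step isolates this amide change, so the expected movement is uncertain. Compound 3 is therefore expected at 30000 nM (range 5000 nM to 100000 nM), an expected step of an at least 1.6-fold lower number from compound 2 to compound 3 (0.22 log units; that floor lies within the scatter).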

Compound 3, half-maximal inhibitory concentration: > 50000 nM
Compound 3: no number, only a limit; the forecaster's own chance of this, stated with the estimate: 50%; middle value at least 1.6-fold (0.22 log units) away from the limit.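

Compound 2 and compound 3 both stand at a limit in this assay, so no step between them can be read: the limit of > 50000 nM in this assay, at which 2 of the 3 values shown sit.

The compounds shown leave open whether 1-phenylethyl or butyl on the amide-type nitrogen gives the lower number, and what the chain alone contributes.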